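The source may hold more compounds than are shown below. What is called first, only, known or untested is meant among the compounds shown, and "the series" means these compounds.

Series notes, cytotoxicity set.

The shared core carries an aryl-terminated chain on the diketone side. Compound 3 `O=C(CCCCCCc1ccccc1)CC(=O)N[C@H]1CCOC1=O` gives 65000 nM in a functional assay on NCI-H630 cells (Homo sapiens) for cytotoxicity, read by sulforhodamine B assay, with a stated time of 5 days; on this read-out lower numbers stand for stronger inhibition and higher numbers for weaker inhibition. Compound 2 `O=C(CCCCCc1ccccc1)CC(=O)N[C@H]1CCOC1=O` gives 44000 nM in this assay. The difference between these two is phenyl in place of benzyl on a saturated chain carbon, five bonds along the chain from a carbonyl carbon, and the step it made is a 1.5-fold lower number from compound 3 to compound 2 (0.17 log units; within the scatter). Compound 1 `O=C(CCCc1ccccc1)CC(=O)N[C@H]1CCOC1=O` is the limit case: in this assay compound 1 gives only a limit, > 100000 nM, and the limit of > 100000 nM in this assay, at which 1 of the 3 values shown sits, records that this is where its value sits. How the core of compound 1 differs from that of compound 3 is not broken down here.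

The unmeasured compound 4 `O=C(CCc1ccccc1)CC(=O)N[C@H]1CCOC1=O` stands to compound 1 as compound 2 stands to compound 3: the difference is phenyl in place of benzyl on a saturated chain carbon, two bonds along the chain from a carbonyl carbon. The place is not identical, however; in compound 3 to compound 2 the change is made two bonds along the chain from a carbonyl carbon, whereas in compound 1 to compound 4 it is made five bonds along the chain from a carbonyl carbon, so the two are the same kind of change rather than the same change.

For compound 4 the expected step is a step that the limit leaves unreadable from compound 1 to compound 4, set beside the measured 1.5-fold lower number from compound 3 to compound 2 (0.17 log units; within the scatter), and it rests on compound 1 having given only the limit > 100000 nM and on the earlier step lying within the scatter. Compound 4 is therefore estimated at 150000 nM, with a range from 60000 nM to 400000 nM in this assay, and a limit rather than a number is the more likely outcome.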

Compound 4, half-maximal inhibitory concentration: > 100000 nM
Compound 4 was reported as a limit; the forecaster's own chance of this, stated with the estimate: 70%; the middle value lies beyond the limit too.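

Compound 1 and compound 4 are both reported only as a limit, not as a number, so no step between them can be read in this assay: the limit of > 100000 nM in this assay, at which 2 of the 4 values shown sit.

As far as these compounds go, what stays open is where the values of compound 1 and compound 4 actually lie, and whether phenyl in place of benzyl, on a saturated chain carbon two bonds along the chain from a carbonyl carbon, changes the read-out at all.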